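The source may report more compounds than this note shows. Statements on the series, on what has been measured and on what is new or still open speak of the compounds shown alone.

Compound 3 `COc1cc2c(cc1O)CCC(C)(CC(N)=O)O2` gives 100% in an ADME assay on SH-SY5Y cells (Homo sapiens) for cytotoxicity, read by MTT assay, with a stated time of 24 h, tested at 25 uM (a lower number here means a stronger effect, a higher number a weaker effect of the compound at the concentration tested), level with compound 1 `COc1cc2c(cc1O)CCC(C)(CC(=O)N[C@@H](C)C(=O)O)O2` at 100%; together these two are the highest of the three numbers, while compound 2 `COc1cc2c(cc1O)CCC(C)(CC(=O)N[C@H](C(=O)O)C(C)C)O2` gives 76.1%. The step of no change at the digits printed from compound 1 to compound 3 (within the scatter) lies within the scatter, whereas a number 23.9 percentage points higher from compound 2 to compound 3 (beyond the scatter) is modest. Compound 4 `COc1cc2c(cc1O)CCC(C)(CCNC(C)=O)O2` carries acetamidomethyl in place of carbamoyl on a saturated chain carbon bound to a saturated ring carbon. Within the data shown here, every measured step alters what sits on the amide-type nitrogen; none exchanges the carbamoyl group itself, so the change toward compound 4 has no direct counterpart among them. The nearest lead is the step of no change at the digits printed from compound 1 to compound 3 (within the scatter), which moved nothing beyond the scatter, and accordingly no step beyond the scatter is expected in this assay. Compound 4 is therefore estimated at 97%, within 84% to 100%, a step of a number 3 percentage points lower from compound 3 to compound 4 (within the scatter) that is expected to stay within the scatter.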

Compound 4, a percentage reported as activity, at one concentration (the size of the read-out at that concentration, not a potency): 76.2%
Beside the measured number, compound 4's estimate is 20.8 percentage points above it; measured number outside the range, below it.
By their numbers in this assay, from the lowest: compounds 2 and 4 (each within the scatter of the next); then compounds 1 and 3 (each within the scatter of the next).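

In this assay, the exchange on a saturated chain carbon bound to a saturated ring carbon gives a number 23.8 percentage points lower from compound 3 to compound 4 (beyond the scatter) and so shows that carbamoyl cannot be replaced by acetamidomethyl without a change in this read-out. Among these compounds, the earlier steps altered only what sits on the amide-type nitrogen, so this is the first change of the group itself. Nothing measured here bears on the origin of this step. The compounds shown leave open whether the step goes with the longer chain or with the acetamido group itself. A primary amine or a carboxylic acid at the end of the same chain would help separate the two.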